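The compounds below may be only part of what the source reports. "The series", "measured", "known", "first", "only" and "open" are said of these compounds alone.

Measured so far in a physicochemical assay for lipophilicity; on this read-out lower numbers stand for lower lipophilicity and higher numbers for higher lipophilicity:

Compound 1 `O=C(Nc1ccccc1Cl)N1CCN(c2nc(-c3ccc4ccccc4n3)no2)CC1`: 2.95
Compound 2 `O=C(Nc1ccccc1Cl)N1CCC(c2nc(-c3ccc4ccccc4n3)no2)CC1`: 4.25

Compound 2 stands highest of these two compounds, at 4.25. Compound 1, at 2.95, lies lower, and that gap is beyond the usual scatter of repeated measurements. These two compounds do not form a step that isolates a single change, so their values give no direct guide to what comes next.

The next compound to be measured is compound 3 `CS(=O)(=O)c1ccc(NC(=O)N2CCC(c3nc(-c4ccc5ccccc5n4)no3)CC2)c(Cl)c1`. It differs from compound 2 in one place: methylsulfonyl in place of hydrogen on an aromatic carbon. Methylsulfonyl stands in place of hydrogen on an aromatic carbon, meta to a chloro group and para to a large group, so 2-chlorophenyl becomes 2-chloro-4-(methylsulfonyl)phenyl.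

Going by the values given here, with no measured step to lean on, the expectation rests on this structural change alone. A downward move in this assay, clearly beyond the scatter, is expected. The estimated size of that move is a number 1.05 log units lower from compound 2 to compound 3 (beyond the scatter). For compound 3 the expected value is 3.2. The estimated range for compound 3 runs from 2.7 to 3.7.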

Compound 3, distribution coefficient: 2.8
Beside the measured number, compound 3's estimate is 0.40 log units above it; low and high end bracket the measured number.
By their numbers in this assay, from the lowest: compounds 3 and 1 (each within the scatter of the next); then compound 2.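

In this assay, going by these compounds alone, turning 2-chlorophenyl into 2-chloro-4-(methylsulfonyl)phenyl gives a number 1.45 log units lower from compound 2 to compound 3 (beyond the scatter), the first measured step here that isolates a single change. It shows that this aromatic carbon, meta to the chloro group and para to a large group, is not a silent place for this read-out: putting methylsulfonyl there in place of hydrogen, with no net charge added, is enough to produce a large step. Nothing available explains why the step has this size.

The compounds shown carry only this one group at this position, so it remains open whether a nitrile, a methoxy group or an amine there would give a step of similar size or direction. Also open, on these data alone, is whether methylsulfonyl would give a comparable step on another aromatic carbon of the same ring, or when placed on the core of compound 1.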